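A few compounds are considered here, and "the series" means these few. Any claim that something is new, unique, unknown or untested is made for them only; others in the source may bear on it.

Compound 1, `O=C(Nc1ccc(F)cc1)c1ccc(NCc2cccc(B(O)O)c2)nc1`, is the point of departure. In a functional assay on RBL cells for antagonist activity at C-X-C chemokine receptor type 1 (Homo sapiens), read by fluorescence and calcium flux, with a stated time of 30 min (on this read-out higher numbers stand for weaker inhibition and lower numbers for stronger inhibition), compound 1 gives 611 nM. Compound 2, `CN(Cc1cccc(B(O)O)c1)c1ccc(C(=O)Nc2ccc(F)cc2)cn1`, carries one change relative to compound 1, (methyl in place of hydrogen on a nitrogen on an aromatic ring), and in this assay compound 2 gives 4100 nM, which corresponds to a 6.7-fold higher number from compound 1 to compound 2 (0.83 log units; beyond the scatter).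

Compound 3, `O=C(Nc1ccc(F)cc1)c1cnc(NCc2ccc(B(O)O)cc2)nc1`, rests on a different core, and the difference between the two cores is not broken down here. In this assay compound 3 gives 1700 nM, which places it between compound 1 and compound 2.

Compound 4, `CN(Cc1ccc(B(O)O)cc1)c1ncc(C(=O)Nc2ccc(F)cc2)cn1`, has not yet been measured. Within the data shown here, it differs from compound 3 by methyl in place of hydrogen on a nitrogen on an aromatic ring, and that is the same change as the one made from compound 1 to compound 2, with the same surroundings at the place of change. Among the measured compounds shown here, the account therefore expects the step from compound 3 to compound 4 to resemble the earlier one, because a 6.7-fold higher number from compound 1 to compound 2 (0.83 log units; beyond the scatter) is the only direct precedent, and it estimates a 5.3-fold higher number from compound 3 to compound 4 (0.72 log units; beyond the scatter). On that basis compound 4 is expected to give about 9000 nM in this assay, with a plausible range from 3500 nM to 25000 nM.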

Compound 4, half-maximal inhibitory concentration: 681 nM
For compound 4 the middle estimate is 13-fold (1.12 log units) above the measured one, outside the stated range (below it).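

On the core of compound 3, methyl in place of hydrogen on a nitrogen on an aromatic ring gives a 2.5-fold lower number from compound 3 to compound 4 (0.40 log units; beyond the scatter) in this assay, so the step seen on the core of compound 1 does not carry over in direction or in size: the same change on two cores in this assay, a 6.7-fold higher number (0.83 log units; beyond the scatter) from compound 1 to compound 2 and a 2.5-fold lower number (0.40 log units; beyond the scatter) from compound 3 to compound 4, 17-fold (1.22 log units) apart, beyond the scatter of two such steps This shows that, in this series, the outcome of this change on one core cannot be taken as a guide to its outcome on another. It does not show what lies behind the reversal, since the two pairs differ from each other in more than one place and the data cannot assign the gap to any one of those differences.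

The compounds shown leave open how an ethyl group or a longer chain on the same nitrogen would behave on either core. They also leave open whether a carboxylic acid in place of the boronic acid would give steps that follow the same split.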